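The source may hold more compounds than are shown below. What is called first, only, known or untested is meant among the compounds shown, and "the series" means these compounds.

In an assay on isolated protein for inhibition of histone deacetylase 8 (Homo sapiens), with a stated time of 1 h (on this read-out lower numbers stand for stronger inhibition and higher numbers for weaker inhibition), compound 1 `O=C(COc1ccc2cc(/C=C3/SC(=O)NC3=O)ccc2c1)Nc1cccc(C(F)(F)F)c1` gives > 50000 nM, which is a limit of the assay rather than a number. Compound 2 `Cc1cccc2sc(NC(=O)COc3ccc4cc(/C=C5/SC(=O)NC5=O)ccc4c3)nc12` gives 5800 nM. Compound 3 `COc1ccc(NC(=O)COc2ccc3cc(/C=C4/SC(=O)NC4=O)ccc3c2)cc1` gives > 50000 nM, again a limit.

Among the compounds with values here, compound 3 therefore stands at the limit of > 50000 nM in this assay, at which 2 of the 3 values shown sit, and only the step of an at least 8.6-fold higher number from compound 2 to compound 3 (0.93 log units; beyond the scatter) is readable; the step that the two limits leave unreadable from compound 1 to compound 3. Compound 4 `O=C(COc1ccc2cc(/C=C3/SC(=O)NC3=O)ccc2c1)Nc1c(F)cc(F)cc1Br` differs from compound 3 by 2-bromo-4,6-difluorophenyl in place of 4-methoxyphenyl on an amide-type nitrogen. The two measured aryl amides, compound 1 and compound 3, both sit at the limit, while the step of an at least 8.6-fold lower number from compound 1 to compound 2 (0.93 log units; beyond the scatter) shows that only the benzothiazole amide reached a number. For compound 4 the expected outcome is thus a step that the limit leaves unreadable from compound 3 to compound 4, most likely another limit, with an estimate of 60000 nM (range 15000 nM to 200000 nM).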

Compound 4, half-maximal inhibitory concentration: > 50000 nM
Compound 4 gave a limit, no number; the forecaster's own chance of this, stated with the estimate: 75%; the middle value does not contradict the limit.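

The bromo-difluoro ring on the amide-type nitrogen also ends at a limit, not a number, so three differently substituted phenyl amides now share one outcome: the limit of > 50000 nM in this assay, at which 3 of the 4 values shown sit.

Within the data shown here, the one step that can be read is an at least 8.6-fold higher number from compound 2 to compound 4 (0.93 log units; beyond the scatter), which leaves compound 2, with its 4-methyl-1,3-benzothiazol-2-yl group, as the only compound here with a number. Steps among compound 1, compound 3 and compound 4 cannot be read, so these three cannot be ranked.

As far as these compounds go, whether any phenyl amide can reach a number stays open. So does the outcome with a pyridine ring or an unsubstituted benzothiazol-2-yl group on this nitrogen.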